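The compounds below may be only part of what the source reports. "The series", "measured", "known", "first", "only" and "open" are said of these compounds alone.

Of the compounds shown here, three sharing one core have been tested in a functional assay on ECa-109 cells for inhibition, with ECa-109 cell line (Homo sapiens) as the target, read by sulforhodamine B assay; on this read-out lower numbers stand for stronger inhibition and higher numbers for weaker inhibition. In this assay, compound 1 (`O=C1C(Nc2ccccc2F)=CC(=O)c2c1nc1n2[C@H]2OC[C@@H](O)[C@H]2OC1`) gives 2660 nM, compound 2 (`COc1ccc(NC2=CC(=O)c3c(nc4n3[C@H]3OC[C@@H](O)[C@H]3OC4)C2=O)cc1`) gives 3410 nM and compound 3 (`COc1cccc(NC2=CC(=O)c3c(nc4n3[C@H]3OC[C@@H](O)[C@H]3OC4)C2=O)c1`) gives 3340 nM. Compound 3 cannot be separated from either of the other two. The measured steps to it are a 1.3-fold higher number from compound 1 to compound 3 (0.10 log units; within the scatter) and a 1.0-fold lower number from compound 2 to compound 3 (0.01 log units; within the scatter).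

The next compound, compound 4 (`CCCc1ccc(NC2=CC(=O)c3c(nc4n3[C@H]3OC[C@@H](O)[C@H]3OC4)C2=O)cc1`), has not yet been measured. It carries 4-propylphenyl in place of 3-methoxyphenyl on an amine nitrogen.

All three measured steps changed the group at this same place, so they are the ones that bear on the new change. Alongside the two steps above, the third is a 1.3-fold higher number from compound 1 to compound 2 (0.11 log units; within the scatter). None of the three exceeds the scatter, although they cover a 2-fluorophenyl group and two methoxyphenyl groups. Going by the values given here, still, no measured compound has a propyl group, and the data do not show how such a chain would behave, so the expected range is kept wide.

No shift beyond the scatter is expected, and the estimated step is a 1.1-fold lower number from compound 3 to compound 4 (0.05 log units; within the scatter). For compound 4 the estimated value in this assay is 3000 nM, with an expected range from 1300 nM to 7000 nM.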

Compound 4, half-maximal inhibitory concentration: > 4000 nM
Compound 4: a limit, no number; the forecaster's own chance of this, stated with the estimate: 5%; at least 1.3-fold (0.12 log units) between middle value and limit.
By their numbers in this assay, from the lowest: compounds 1, 3 and 2 (each within the scatter of the next). At a limit, above all of these: compound 4.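

In this assay compound 4 gives a limit and not a number, the only such result among the compounds shown: the limit of > 4000 nM in this assay, at which 1 of the 4 values shown sits. The comparisons therefore exist only as floors: an at least 1.1-fold higher number from compound 3 to compound 4 (0.07 log units; that floor lies within the scatter), an at least 1.1-fold higher number from compound 2 to compound 4 (0.06 log units; that floor lies within the scatter) and an at least 1.5-fold higher number from compound 1 to compound 4 (0.17 log units; that floor lies within the scatter). The 2-fluorophenyl and methoxyphenyl groups on the amine nitrogen gave numbers that could not be separated from one another, whereas 4-propylphenyl at the same place shows no gain in inhibition, and its floors do not establish a real loss either.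

On these data alone, the actual value of compound 4 stays open, and with it the true size of the change from 3-methoxyphenyl to 4-propylphenyl. Also open, as far as these compounds go, is what an ethyl group, a longer chain such as butyl, or a propyl chain carrying an amine or a carboxylic acid would give on the phenyl ring at this place.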